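The source may report more compounds than this note shows. Statements on the series, on what has been measured and on what is new or still open speak of the compounds shown alone.

Measured compounds:
- compound 1, `COCC(=O)N1C[C@@H](C)N(c2ncc3[nH]nc(-c4ccc(N5CCN[C@H](C)C5)nc4)c3n2)[C@@H](C)C1`: 7.3 nM in an assay on Sf9 cells for inhibition of activin receptor type-1 (Homo sapiens), read by HTRF, with a stated time of 3 h, in the presence of a further agent that is not named here; a higher number here means a weaker inhibitor, a lower number a stronger inhibitor
- compound 2, `C[C@@H]1CN(c2ccc(-c3n[nH]c4ccc(N5CCCCC5)nc34)cn2)CCN1`: 95 nM in this assay

Compound 1 holds the lowest number of the two in this assay; compound 2 sits well above it, and the gap between the two values is beyond the usual scatter. The two structures differ in several places at once, so nothing is drawn from that pair beyond the two values themselves.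

Compound 3, `COC(=O)N1C[C@@H](C)N(c2ncc3[nH]nc(-c4ccc(N5CCN[C@H](C)C5)nc4)c3n2)[C@@H](C)C1`, is the closest relative of compound 1: the only difference is methoxy in place of methoxymethyl on a carbonyl carbon. Among the compounds with values here, the acyl group on the ring nitrogen is shortened by one carbon at a site away from the remainder of the molecule, and no measured pair describes such a change here. The expectation is therefore no step beyond the scatter in this assay, with the estimate for compound 3 set at 9 nM (range 3 nM to 27 nM), which is an expected step of a 1.2-fold higher number from compound 1 to compound 3 (0.09 log units; within the scatter).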

Compound 3, half-maximal inhibitory concentration: 0.85 nM
For compound 3 the middle estimate is 11-fold (1.02 log units) above the measured one; the measured number lies below the stated range.
By their numbers in this assay, from the lowest: compound 3; then compound 1; then compound 2.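

The acyl group on the ring nitrogen is not a silent site in this assay: methoxy in place of methoxymethyl on the carbonyl carbon gives an 8.6-fold lower number from compound 1 to compound 3 (0.93 log units; beyond the scatter) and so moves the number beyond the scatter. The group leaving has 3 heavy atoms and the one entering has 2, with the hydrogen-bond acceptor count of 1 the same on both sides, so a small edit at this carbonyl carbon is enough to shift the value. Nothing available bears on the reason for this step.

A single pair does not separate the length of the group from the identity of the atom bound to the carbonyl carbon. Ethoxy, methylamino or a plain methyl on the same carbonyl carbon would address that, and the reach of the step beyond the core of compound 1 remains open.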